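A small swap on a saturated ring carbon

This account rests on a few compounds, and the source may have more. Where it says the series, first, only, none or still open, it means among the compounds named here.

compound 1 `CC(C)N(C)[C@@H]1CC[C@H](N2CC[C@H](NC(=O)c3cccc(C(F)(F)F)c3)C2=O)[C@H](NS(C)(=O)=O)C1` gives 85% remaining
compound 2 `CC(C)N(C)[C@@H]1CC[C@H](N2CC[C@H](Nc3ncnc4ccc(C(F)(F)F)cc34)C2=O)[C@H](CS(C)(=O)=O)C1` gives 99% remaining

In an ADME assay on microsomes from liver (Homo sapiens) for metabolic stability, with a stated time of 10 min, tested at 3 uM (a lower number here means that less of the compound is left, a higher number that more of the compound is left), compound 2 has the higher of the two numbers with 99% left, and compound 1 lies lower, beyond the usual scatter, with 85% left.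

The next compound, compound 3 `CC(C)N(C)[C@@H]1CC[C@H](N2CC[C@H](Nc3ncnc4ccc(C(F)(F)F)cc34)C2=O)[C@H](NS(C)(=O)=O)C1`, keeps the rest of compound 2 and places methanesulfonamido in place of (methylsulfonyl)methyl on a saturated ring carbon. Among the compounds with values here, no measured pair shows this change alone. Compound 1 carries the same methanesulfonamido group on a different remainder, and its 85% in this assay is only a loose guide, pointing to a slightly lower number. The expected change, a number 8 percentage points lower from compound 2 to compound 3 (within the scatter), is a small fall that would stay within the scatter. Compound 3 is expected to give 91% within an estimated range from 78% to 100% when measured.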

Compound 3, percent of the compound remaining: 58%
For compound 3 the middle estimate is 33 percentage points above the measured one; the whole stated range lies above it.
By their numbers in this assay, from the lowest: compound 3; then compound 1; then compound 2.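

In this assay the swap of (methylsulfonyl)methyl for methanesulfonamido gives a number 41 percentage points lower from compound 2 to compound 3 (beyond the scatter) even though both groups have 5 heavy atoms, so this saturated ring carbon responds strongly to a change that adds only 1 hydrogen-bond donor and puts a nitrogen where a carbon stood. The same methanesulfonamido group does not give one fixed result, since compound 1 keeps 85% while compound 3 keeps 58% with a different remainder. Nothing at hand explains why the number falls at this position.

The compounds shown leave open whether the fall follows the nitrogen link itself or the sulfonyl group it carries. They also leave open how an amine, a carboxylic acid or a longer chain on this ring carbon would behave.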